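A few compounds are considered here, and "the series" means these few. Any claim that something is new, unique, unknown or untested is made for them only; others in the source may bear on it.

Measured compounds:
compound 1 `CCCCn1cnc2[nH]c(=O)[nH]c(=O)c21`, in an assay on cell membranes from brain for binding affinity to adenosine receptor A1 (Rattus norvegicus), read by radioligand binding (a lower number here means a stronger inhibitor, a higher number a weaker inhibitor), compound 1 gives 27000 nM
compound 2 `C=CCn1cnc2c1c(=O)[nH]c(=O)n2CC=C`, compound 2 gives 36000 nM
compound 3 `CCCn1c(=O)[nH]c2ncn(C)c2c1=O`, compound 3 gives 21000 nM

Compound 3 holds the lowest of the three numbers shown, yet its gaps to compound 1 and to compound 2 both lie within the scatter, so the three measured compounds cannot be separated in this assay.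

Compound 4 `C#CCn1c(=O)[nH]c2ncn(C)c2c1=O` differs from compound 3 by ethynyl in place of ethyl on a saturated chain carbon bound to an aromatic nitrogen. Among the measured compounds shown here, no measured pair shows this change. The three measured numbers sit close together across quite different chain patterns, so no step beyond the scatter is expected, with at most a slight lean toward a lower number.

Compound 4 is therefore expected near 15000 nM in this assay, with a range of 5000 nM to 50000 nM. The expected step is a 1.4-fold lower number from compound 3 to compound 4 (0.15 log units; within the scatter).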

Compound 4, inhibition constant: 22000 nM
Estimate against measurement, compound 4: 1.5-fold (0.17 log units) below; the range from low to high includes it.
By their numbers in this assay, from the lowest: compounds 3, 4, 1 and 2 (each within the scatter of the next).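

This gives the series its first comparison that differs in one place: on the saturated chain carbon bound to an aromatic nitrogen, ethynyl in place of ethyl in this assay gives a 1.0-fold higher number from compound 3 to compound 4 (0.02 log units; within the scatter) and stays within the scatter. Propyl to propargyl therefore leaves the number unchanged, and a triple bond at this chain end brings no readable gain or loss. Nothing available gives a reason for this result.

From the compounds shown here alone, whether an amine, a carboxylic acid or a longer chain at this position would give a step beyond the scatter remains open.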